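Swapping the Outer Aryl Group of Compound 2

The source may hold more compounds than are shown below. What is called first, only, known or untested is meant among the compounds shown, and "the series" means these compounds.

Compound 2 `COc1cccc(CNCCCNc2ccnc3cc(-c4ccc(C(C)(C)C)cc4)ccc23)c1O` gives 690 nM in an ADME assay on HepG2 cells (Homo sapiens) for cytotoxicity, read by luminescence, CellTiter-Glo and ATP content, with a stated time of 72 h (a lower number here means that less compound is needed, a higher number that more compound is needed for the effect), the lowest of the three numbers in hand. Its nearest neighbour is compound 3 `CC(C)(C)c1ccc(-c2ccc3c(NCCCNCc4ccco4)ccnc3c2)cc1`, at 3150 nM, reached by a 4.6-fold higher number from compound 2 to compound 3 (0.66 log units; beyond the scatter); compound 1 `Fc1ccc(-c2ccc3c(NCCCNCc4ccco4)ccnc3c2)cc1`, at 7760 nM, stands furthest away. Compound 4 `COc1ccccc1Oc1ccc2c(NCCCNCc3cccc(OC)c3O)ccnc2c1` differs from compound 2 by 2-methoxyphenoxy in place of 4-(tert-butyl)phenyl on an aromatic carbon. Among the measured compounds shown here, no measured step covers this exchange. For the measured compounds named here, the only step at the same position is a 2.5-fold lower number from compound 1 to compound 3 (0.39 log units; beyond the scatter), which shows that the group there shifts the number modestly. A modest rise is therefore expected for compound 4, by a 2.6-fold higher number from compound 2 to compound 4 (0.42 log units; beyond the scatter). The range is kept wide, as nothing measured tests this particular group. Compound 4 is thus estimated at 1800 nM, between 700 nM and 5000 nM.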

Compound 4, half-maximal effective concentration: 11200 nM
Estimate against measurement, compound 4: 6.2-fold (0.79 log units) below, and the stated range ends below it.
By their numbers in this assay, from the lowest: compound 2; then compound 3; then compounds 1 and 4 (each within the scatter of the next).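

At this place on the core, 2-methoxyphenoxy in place of 4-(tert-butyl)phenyl gives a 16-fold higher number from compound 2 to compound 4 (1.21 log units; beyond the scatter) in this assay, a large step. Among the compounds shown here, the only earlier step here, a 2.5-fold lower number from compound 1 to compound 3 (0.39 log units; beyond the scatter), was modest, so this position can move the number much further than that exchange showed. No measurement at hand accounts for the size of this step. Open, on these data alone, is whether an unsubstituted phenoxy or a 2-methoxyphenyl would give a similar rise. Also open, as far as these compounds go, is whether the step holds with furan-2-yl on the chain.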